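Replacing sec-butyl with 2-carbamoylethyl in compound 1

The compounds below may be only part of what the source reports. "The series", "measured", "known", "first", "only" and "open" are said of these compounds alone.

Going by the values given here, in a toxicity assay on cells (Erythrocyte, Homo sapiens) for cytotoxicity, read by hemolysis (a lower number here means that less compound is needed, a higher number that more compound is needed for the effect), compound 1 `CCCCCCCCCCCCCC(=O)NCc1ccc(C(=O)N[C@H](C(=O)O)[C@@H](C)CC)cc1` gives 66 ug/mL, the lower of the two numbers so far, while compound 2 `CCCC/C=C\CCCCCCCC(=O)NCc1ccc(C(=O)N[C@H](C(=O)O)[C@@H](C)CC)cc1` gives 350 ug/mL. Compound 3 `CCCCCCCCCCCCCC(=O)NCc1ccc(C(=O)N[C@@H](CCC(N)=O)C(=O)O)cc1` has 2-carbamoylethyl in place of sec-butyl on a saturated chain carbon bound to an amide-type nitrogen and a carbonyl carbon. Among the compounds with values here, the only measured step, a 5.3-fold higher number from compound 1 to compound 2 (0.72 log units; beyond the scatter), replaces hexyl rather than sec-butyl, so it serves only as a rough guide to size. A step of somewhat smaller size towards a higher number is therefore expected, though with wide uncertainty: the estimated change is a 3.0-fold higher number from compound 1 to compound 3 (0.48 log units; beyond the scatter). The expected value for compound 3 is 200 ug/mL, within an estimated range of 70 ug/mL to 600 ug/mL.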

Compound 3, half-maximal effective concentration: 520 ug/mL
Compound 3: the middle estimate sits 2.6-fold (0.41 log units) below what was measured, and the stated range covers the measured number.
By their numbers in this assay, from the lowest: compound 1; then compounds 2 and 3 (each within the scatter of the next).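

In this assay, the group on the saturated chain carbon bound to an amide-type nitrogen and a carbonyl carbon also matters: 2-carbamoylethyl in place of sec-butyl gives a 7.9-fold higher number from compound 1 to compound 3 (0.90 log units; beyond the scatter). Going by these compounds alone, the earlier compounds showed only a change in the long chain, a 5.3-fold higher number from compound 1 to compound 2 (0.72 log units; beyond the scatter), so this is the first sign that a second place on the molecule affects hemolysis. No supporting measurement bears on why the number moves. From the compounds shown here alone, whether an amine or a carboxylic acid in place of the carbamoyl end of 2-carbamoylethyl would shift the number as far remains open, as does whether this change would act the same way on the chain of compound 2.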